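The source may report more compounds than this note shows. Statements on the series, on what has been measured and on what is new or still open speak of the compounds shown alone.

Measured compounds:
- compound 1, `C[C@@H]1CCCN1c1c(C#N)c2c(N)nc(Nc3cn[nH]c3)nc2n1C`, gives 0.4 nM in an assay on isolated protein for binding affinity to Leucine-rich repeat serine/threonine-protein kinase 2 variant G2019S (Homo sapiens), read by TR-FRET and LanthaScreen, with a stated time of 2 h; on this read-out lower numbers stand for stronger inhibition and higher numbers for weaker inhibition
- compound 2, `C[C@@H]1CCCN1c1c(C#N)c2c(N)ncnc2n1C`, gives 0.7 nM in this assay
- compound 3, `C[C@@H]1CCCN1c1cc2c(N)ncnc2n1C`, gives 439 nM in this assay

Compound 3 stands at the highest number of the three, that is, the weakest binding in this assay. The two steps that lead to it show how the series behaves: removing the pyrazolylamino group gave a 1.8-fold higher number from compound 1 to compound 2 (0.24 log units; within the scatter), whereas removing the cyano group gave a 630-fold higher number from compound 2 to compound 3 (2.80 log units; beyond the scatter). The first change scarcely mattered; the second was large.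

Compound 4, `C[C@@H]1CCCN1c1c(C(N)=O)c2c(N)ncnc2n1C`, has not been measured in this assay. It differs from compound 3 in one place: carbamoyl in place of hydrogen on an aromatic carbon, on the same aromatic carbon that carries the cyano group in compound 2. Going by the values given here, only one measured step bears on this position, the one from compound 2 to compound 3, and it was very large, so a substituent here is expected to bring the number down again well beyond the scatter. Carbamoyl is not cyano, however, so full return to the level of compound 2 is uncertain. The estimate for compound 4 is therefore a 29-fold lower number from compound 3 to compound 4 (1.47 log units; beyond the scatter), giving 15 nM with a range from 2 nM to 120 nM.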

Compound 4, inhibition constant: 154 nM
Compound 4: the middle estimate sits 10-fold (1.01 log units) below what was measured; the whole stated range lies below it.
By their numbers in this assay, from the lowest: compounds 1 and 2 (each within the scatter of the next); then compound 4; then compound 3.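

Until now the series showed only that taking the nitrile off this aromatic carbon costs a great deal of binding, which left open whether any group placed there would restore it. Carbamoyl on this carbon wins back only a small part of that loss in this assay: adding it to the bare ring carbon brings a 2.9-fold lower number from compound 3 to compound 4 (0.45 log units; beyond the scatter) and, set against the nitrile, it brings a 220-fold higher number from compound 2 to compound 4 (2.34 log units; beyond the scatter). The very low number of compound 2 therefore depends on which group sits here and not merely on the carbon carrying a substituent, yet nothing among the available data explains the gap between these two groups.

With only hydrogen, carbamoyl and nitrile shown on this carbon, it remains open how a chlorine atom, a methyl group or a carboxylic acid would compare with the nitrile. On these data alone, it is also open whether the (1H-pyrazol-4-yl)amino group, whose removal from compound 1 left the number within the scatter, would matter as little on a core carrying carbamoyl in place of the nitrile.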